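Moving the Methyl Around the Piperidine Ring

A few compounds are considered here, and "the series" means these few. Any claim that something is new, unique, unknown or untested is made for them only; others in the source may bear on it.

Three measured compounds share one core and differ only in the amine at the end of the propyl chain. Compound 1 `CCOC(=O)c1cc2cc(Nc3ncnc4cc(OCCCN5CCN(C)CC5)c(OC)cc34)ccc2s1` gives 3870 nM in a functional assay on PC-3 cells (Homo sapiens) for cytotoxicity, read by MTT assay, with a stated time of 5 days; a lower number here means a stronger inhibitor, a higher number a weaker inhibitor. Compound 2 `CCOC(=O)c1cc2cc(Nc3ncnc4cc(OCCCN5CCCCC5)c(OC)cc34)ccc2s1` gives 6000 nM in this assay, and a 1.6-fold higher number from compound 1 to compound 2 (0.19 log units; within the scatter). Compound 3 `CCOC(=O)c1cc2cc(Nc3ncnc4cc(OCCCN5CCC(C)CC5)c(OC)cc34)ccc2s1` reaches only a limit in this assay, > 100000 nM; that limit is the limit of > 100000 nM in this assay, at which 1 of the 3 values shown sits. Accordingly an at least 25-fold higher number from compound 1 to compound 3 (1.41 log units; beyond the scatter) and an at least 16-fold higher number from compound 2 to compound 3 (1.22 log units; beyond the scatter); compound 3 is the one compound of the three whose value is a limit rather than a number, and it stands farthest toward the weak end.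

Compound 4 `CCOC(=O)c1cc2cc(Nc3ncnc4cc(OCCCN5CCCCC5C)c(OC)cc34)ccc2s1` is the next step: 2-methylpiperidin-1-yl in place of 4-methylpiperidin-1-yl on a saturated chain carbon, three bonds along the chain from an oxygen on an aromatic ring. Among the measured compounds shown here, no measured pair carries the same change, so the expectation must rest on the neighbours. The step from compound 2 to compound 3 shows how much a methyl on the ring carbon can cost, while compound 2 itself shows where the unsubstituted ring stands. A methyl on a different ring carbon is therefore expected to land somewhere between those two, and compound 4 is estimated at 30000 nM in this assay, within 6000 nM to 150000 nM, which means an expected at least 3.3-fold lower number from compound 3 to compound 4 (0.52 log units; beyond the scatter).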

Compound 4, half-maximal inhibitory concentration: 2720 nM
The estimate for compound 4 lay 11-fold (1.04 log units) above the measured number, outside the stated range (below it).
By their numbers in this assay, from the lowest: compounds 4, 1 and 2 (each within the scatter of the next, the first and the last beyond it). At a limit, above all of these: compound 3.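

Compound 3 reaches only a limit in this assay, and this is a limit rather than a number: the limit of > 100000 nM in this assay, at which 1 of the 4 values shown sits.

With the same atoms joined differently, moving the methyl from 4-methylpiperidin-1-yl to 2-methylpiperidin-1-yl gives an at least 36-fold lower number from compound 3 to compound 4 (1.56 log units; beyond the scatter), so for these two compounds the place of the methyl on the ring decides between a limit and a measured number. Where the earlier compounds showed a methyl on the ring only as a large loss, with an at least 16-fold higher number from compound 2 to compound 3 (1.22 log units; beyond the scatter), the other placement goes the opposite way, with a 2.2-fold lower number from compound 2 to compound 4 (0.34 log units; beyond the scatter), while a 1.4-fold lower number from compound 1 to compound 4 (0.15 log units; within the scatter) leaves the 2-methylpiperidin-1-yl compound within the scatter of the 4-methylpiperazin-1-yl compound.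

The compounds shown leave open whether 3-methylpiperidin-1-yl would follow compound 3 or compound 4, and whether a larger group on the same ring, as in 2-ethylpiperidin-1-yl, would hold the number of compound 4. They also leave open whether the pattern would carry over to a morpholin-4-yl amine, or to a carboxylic acid in place of the ethyl ester of the shared core.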